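Compound 3 leads a small, unrelated set

This account rests on a few compounds, and the source may have more. Where it says the series, first, only, none or still open, it means among the compounds named here.

In an ADME assay on L1210/0 cells (Mus musculus) for cytotoxicity, with a stated time of 48 h (on this read-out higher numbers stand for weaker inhibition and lower numbers for stronger inhibition), so far:
- compound 1 `Cc1ccc(-c2ncnc3c2ncn3C[C@@H]2C[C@H](CO)c3ccccc32)cc1` gives 15400 nM
- compound 2 `O=c1[nH]c(=O)n([C@H]2C[C@H](O)[C@@H](CO)O2)cc1/C=N/O` gives 15500 nM
- compound 3 `O=C1O/C(=C\Cn2cc(C(F)(F)F)c(=O)[nH]c2=O)C(OCc2ccccc2)=C1OCc1ccccc1` gives 2000 nM

Compound 3 has the lowest number of the three, and the numbers for compound 1 and compound 2 both lie beyond the scatter above it. Compound 4 `O=C1O/C(=C\Cn2cc(F)c(=O)[nH]c2=O)C(OCc2ccccc2)=C1OCc1ccccc1` carries fluoro in place of trifluoromethyl on an aromatic carbon. Within the data shown here, no two measured compounds differ in one place only, so no measured step guides the size of this change. A modest expected move toward a lower number, a 1.7-fold lower number from compound 3 to compound 4 (0.22 log units; within the scatter) in this assay, may stay within the scatter. For compound 4 the estimated value is 1200 nM, with an expected range from 250 nM to 6000 nM.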

Compound 4, half-maximal inhibitory concentration: 5100 nM
For compound 4 the middle estimate is 4.3-fold (0.63 log units) below the measured one; the range from low to high includes it.
By their numbers in this assay, from the lowest: compound 3; then compound 4; then compounds 1 and 2 (each within the scatter of the next).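

In this assay, among these compounds, this position responds to the group it carries: fluoro in place of trifluoromethyl on an aromatic carbon gives a 2.6-fold higher number from compound 3 to compound 4 (0.41 log units; beyond the scatter) and is the first readable step. Of these two groups, trifluoromethyl goes with the lower number, in this one pair only. No measured evidence on the cause of this step is at hand. From the compounds shown here alone, whether a methyl, a chlorine or a nitrile on the same carbon would give a lower number than compound 3 stays open. So does whether the step would repeat with free hydroxyl groups in place of the benzyl ethers.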